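Nitro for Cyano on Two Related Cores

The source may report more compounds than this note shows. Statements on the series, on what has been measured and on what is new or still open speak of the compounds shown alone.

Compound 1 `CC(O)(CSc1cc(C(F)(F)F)cc(C(F)(F)F)c1)C(=O)Nc1ccc(C#N)cc1C(F)(F)F` and compound 2 `CC(O)(CSc1cc(C(F)(F)F)cc(C(F)(F)F)c1)C(=O)Nc1ccc([N+](=O)[O-])cc1C(F)(F)F` share one core; compound 3 `CC1(C)C(=O)N(c2ccc(C#N)c(C(F)(F)F)c2)C(=S)N1c1cc(C(F)(F)F)cc(C(F)(F)F)c1` and compound 4 `CC1(C)C(=O)N(c2ccc([N+](=O)[O-])c(C(F)(F)F)c2)C(=S)N1c1cc(C(F)(F)F)cc(C(F)(F)F)c1` share another, and the difference between the two cores is not broken down here. In a functional assay on DU-145 cells (Homo sapiens) for antiproliferative activity, read by fluorescence and propidium iodide staining, with a stated time of 96 h (a higher number here means a weaker inhibitor, a lower number a stronger inhibitor), compound 1 gives 9090 nM and compound 2 gives 3380 nM, a step of a 2.7-fold lower number from compound 1 to compound 2 (0.43 log units; beyond the scatter) for the change (nitro in place of cyano on an aromatic carbon). In this assay compound 3 gives "nd(insoluble)" (no result reported), which is no result at all. The change nitro in place of cyano on an aromatic carbon from compound 3 to compound 4 is the same kind of change, though here the place is ortho to a trifluoromethyl group where before it was meta to one. With no number for compound 3, any expectation for compound 4 rests only on compound 2 at 3380 nM, which carries the same nitro group. Compound 4 is therefore expected to give about 4000 nM, within a range of 1200 nM to 15000 nM.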

Compound 4, half-maximal inhibitory concentration: 18100 nM
Compound 4: middle estimate off by 4.5-fold (0.66 log units), on the low side; the measured number lies above the stated range.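

Compound 3 carries no number, so the step from it to compound 4 cannot be read. Whether nitro in place of cyano acts on this core as on that of compound 1 stays open, and nothing at hand explains the result for compound 4.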